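This account rests on a few compounds, and the source may have more. Where it says the series, first, only, none or still open, it means among the compounds named here.

Compound 2 `C/C(=C\COC(=O)NC(C)C)C1=CC(=O)C(C)(C)O1` carries an isopropyl group on the carbamate nitrogen of a shared core. For the measured compounds named here, in a functional assay on MOLT-4F cells (Homo sapiens) for inhibition (a lower number here means a stronger inhibitor, a higher number a weaker inhibitor), compound 2 gives 6.6 ug/mL, the second highest of the three numbers measured so far. Its nearest neighbour is compound 1 `C/C(=C\COC(=O)NC(C)(C)C)C1=CC(=O)C(C)(C)O1`, which in this assay gives 6.1 ug/mL; the furthest is compound 3 `COc1ccc(/C=C/C=C(\C)C2=CC(=O)C(C)(C)O2)cc1`, which gives 10 ug/mL. All three numbers sit close together.

Compound 4 `C/C(=C\COC(=O)NCc1ccccc1)C1=CC(=O)C(C)(C)O1` is made from compound 2 by one change: benzyl in place of isopropyl on an amide-type nitrogen. Going by the values given here, the only measured step that touches the same place is the one from compound 1 to compound 2, where a hydrogen replaced a methyl on the carbon bound to that nitrogen, and that step was a 1.1-fold higher number from compound 1 to compound 2 (0.03 log units; within the scatter). Compound 3 differs from compound 2 in a wider part of the molecule, so only its value, not a single step, can be set beside the others. Among the compounds with values here, with one small step at this position as the sole guide, the expected result for compound 4 in this assay is a step of a 1.1-fold lower number from compound 2 to compound 4 (0.04 log units; within the scatter), which is not beyond the scatter. The estimate for compound 4 is therefore 6 ug/mL, with a range from 3 ug/mL to 12 ug/mL.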

Compound 4, half-maximal inhibitory concentration: 6 ug/mL
Compound 4: middle estimate and measured number agree at the digits printed; the measured number falls inside the stated range.
By their numbers in this assay, from the lowest: compounds 4, 1, 2 and 3 (each within the scatter of the next).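

The earlier step only took one methyl from the carbon bound to the nitrogen, whereas this change places a six-membered aromatic ring of carbon only at that position, and in this assay it is still just a 1.1-fold lower number from compound 2 to compound 4 (0.04 log units; within the scatter). Set against the tert-butyl group, the same exchange gives a 1.0-fold lower number from compound 1 to compound 4 (0.01 log units; within the scatter), so tert-butyl, isopropyl and benzyl on this amide-type nitrogen cannot be told apart in this assay, even though benzyl brings 7 heavy atoms where isopropyl has 3. No supporting data are available to say why these numbers stay so close.

From the compounds shown here alone, all three groups on this nitrogen are built of carbon and hydrogen alone, so what an amine, a carboxylic acid or a longer chain carrying a hydroxyl group would do here remains open. Also open, going by these compounds, is whether a benzyl ring bearing a methoxy group would keep the number in the same range, and compound 3 cannot settle this, as it differs from the others in a wider part of the molecule.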